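This account rests on a few compounds, and the source may have more. Where it says the series, first, only, none or still open, it means among the compounds named here.

Measured so far:
- compound 1, `O=C(O)CCNC(=O)CN(CCOc1ccc2c(c1)CCC2)S(=O)(=O)c1ccc(Cl)cc1Cl`: 410 nM
- compound 2, `COCCCNC(=O)CN(CCOc1ccc2c(c1)CCC2)S(=O)(=O)c1ccc(Cl)cc1Cl`: 1210 nM

Among the measured compounds shown here, in an assay on WI 38 cells for displacement of a labelled ligand from B1 bradykinin receptor (Homo sapiens) (on this read-out lower numbers stand for stronger inhibition and higher numbers for weaker inhibition), compound 1 gives 410 nM, the lower of the two numbers measured so far. Its nearest neighbour is compound 2, and the step of a 3.0-fold higher number from compound 1 to compound 2 (0.47 log units; beyond the scatter) separates them.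

Compound 3, `O=C(O)CCNC(=O)CN(CCOc1ccccc1)S(=O)(=O)c1ccc(Cl)cc1Cl`, has not yet been measured. It differs from compound 1 by phenyl in place of 2,3-dihydro-1H-inden-5-yl on an oxygen on a saturated carbon. For the measured compounds named here, the only measured step, from compound 1 to compound 2, changes a different part of the molecule, the end of the chain carrying the carboxy group, and so says nothing direct about trimming the ring system on the ether oxygen. Going by the values given here, no measured pair informs this change. Compound 3 is therefore expected, with low confidence, to give a higher number than compound 1, a step of roughly a 3.7-fold higher number from compound 1 to compound 3 (0.56 log units; beyond the scatter), on the assumption that the lost five-membered ring contributed to binding. The estimate for compound 3 in this assay is 1500 nM, expected to fall between 400 nM and 6000 nM.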

Compound 3, inhibition constant: 13000 nM
Compound 3: middle estimate off by 8.7-fold (0.94 log units), on the low side; the measured number lies above the stated range.
By their numbers in this assay, from the lowest: compound 1; then compound 2; then compound 3.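

In this assay, phenyl in place of 2,3-dihydro-1H-inden-5-yl on an oxygen on a saturated carbon gives a 32-fold higher number from compound 1 to compound 3 (1.50 log units; beyond the scatter), a much larger step than the change at the other end of the molecule, a 3.0-fold higher number from compound 1 to compound 2 (0.47 log units; beyond the scatter). The change keeps the six-membered aromatic ring and removes only the five-membered non-aromatic ring of carbon, and neither group carries hydrogen-bond donors or acceptors, so a difference in carbon alone is enough here to weaken inhibition strongly. Nothing available explains why this carbon ring matters so much.

On these data alone, it remains open whether a smaller carbon group on the phenyl, such as methyl or ethyl, would recover the inhibition, or whether a larger ring system such as naphthyl would do better. As far as these compounds go, it is also open whether the same step would appear with the methoxymethyl end of compound 2 in place of the carboxy end.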